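The source may report more compounds than this note shows. Statements on the series, on what has been measured and on what is new or still open speak of the compounds shown alone.

Measured so far:
compound 1, `CCCCCCCCCCC[C@@H](C[C@@H]1OC(=O)[C@H]1CCCCCC)OC(=O)CNC(=O)OCc1ccccc1`, in an assay on COS-7 cells for inhibition of diacylglycerol lipase-alpha (Homo sapiens), read by scintillation counting (on this read-out lower numbers stand for stronger inhibition and higher numbers for weaker inhibition), gives > 25000 nM.
compound 2, `CCCCCCCCCCC[C@@H](C[C@@H]1OC(=O)[C@H]1CCCCCC)OC(=O)CCNC=O`, in this assay gives 600 nM.

The value of compound 1 is a limit of the assay, not a number (the limit of > 25000 nM in this assay, at which 1 of the 2 values shown sits). Compound 2 therefore holds the only number shown and stands alone, with no measured neighbour above or below it. Among the compounds with values here, the single measured step, an at least 41-fold lower number from compound 1 to compound 2 (1.61 log units; beyond the scatter), pairs the removal of the large benzyloxycarbonylamino group with a much lower number.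

Compound 3, `CCCCCCCCCCC[C@@H](C[C@@H]1OC(=O)[C@H]1CCCCCC)OC(=O)[C@@H]1CCC(=O)N1`, differs from compound 2 by 5-oxopyrrolidin-2-yl in place of 2-(formylamino)ethyl on a carbonyl carbon. The measured step bears on it only loosely: it concerned a far larger group leaving, whereas here one small amide-bearing group replaces another of similar size. For compound 3 a change of a 2.0-fold higher number from compound 2 to compound 3 (0.30 log units; within the scatter) is expected, modest and likely upward. Compound 3 is estimated at 1200 nM, between 250 nM and 6000 nM.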

Compound 3, half-maximal inhibitory concentration: 100 nM
For compound 3 the middle estimate is 12-fold (1.08 log units) above the measured one, and the stated range ends above it.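

In this assay, the position on the carbonyl carbon turns out to accept a five-membered non-aromatic ring: 5-oxopyrrolidin-2-yl in place of 2-(formylamino)ethyl goes with a 6.0-fold lower number from compound 2 to compound 3 (0.78 log units; beyond the scatter), although the counts of hydrogen-bond donors and acceptors are the same on both sides of the change. Measured against the ((benzyloxycarbonyl)amino)methyl group, the same ring goes with an at least 250-fold lower number from compound 1 to compound 3 (2.39 log units; beyond the scatter). The value of compound 1 in that comparison is a limit of the assay, not a number: the limit of > 25000 nM in this assay, at which 1 of the 3 values shown sits.

The compounds shown leave open whether the lower number depends on the defined stereocentre of the 5-oxopyrrolidin-2-yl group or on the amide within its ring. A plain cyclopentyl ring, the six-membered piperidin-2-one homologue, an amine or a carboxylic acid at this place would each bear on that question.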